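A few compounds are considered here, and "the series" means these few. Any claim that something is new, unique, unknown or untested is made for them only; others in the source may bear on it.

Compound 2 `Cc1ccc(C(=O)Nc2cn3ncnc3c(CN3CCN(C(=O)C4CCCC4)[C@@H](C)C3)c2C)cn1` and compound 1 `Cc1ccc(C(=O)Nc2cc3nncn3c(CN3CCN(C(=O)C4CCCC4)[C@@H](C)C3)c2C)cn1` share one core and differ only in how two ring nitrogens are arranged within it. In an ADME assay on microsomes from liver (Homo sapiens) for metabolic stability (on this read-out lower numbers stand for slow clearance and higher numbers for fast clearance), compound 2 gives 32 mL.min-1.g-1, and compound 1 gives 59 mL.min-1.g-1; the two numbers lie within the scatter of each other, so neither can be called the slower-cleared one. Compound 3 `Cc1ccc(C(=O)Nc2cn3ncnc3c(CN3CCN(C(=O)CC(C(F)(F)F)C(F)(F)F)[C@@H](C)C3)c2C)cn1` keeps the core of compound 2 and changes the amide end: 3,3,3-trifluoro-2-(trifluoromethyl)propyl in place of cyclopentyl on a carbonyl carbon. Among the compounds with values here, no measured pair shows this swap, so the step of a 1.5-fold lower number from compound 2 to compound 3 (0.16 log units; within the scatter) is an expectation only, a small shift towards slower clearance that may not exceed the scatter. Compound 3 is expected to give about 22 mL.min-1.g-1, most likely between 9 mL.min-1.g-1 and 50 mL.min-1.g-1.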

Compound 3, intrinsic clearance in microsomes in the Homo sapiens assay: < 10 mL.min-1.g-1
Compound 3 ended at the assay's limit; the forecaster's own chance of this, stated with the estimate: 5%; at least 2.2-fold (0.34 log units) between middle value and limit.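

Swapping the group on this carbonyl carbon gives a step that can be read in the Homo sapiens assay, which the earlier pair of compounds did not: an at least 3.2-fold lower number from compound 2 to compound 3 (0.50 log units; beyond the scatter). Compound 3 sits at a limit of that assay, so its entry is not a number and the true step may be larger: the limit of < 10 mL.min-1.g-1 in the Homo sapiens assay, at which 1 of the 3 values shown sits.

In a physicochemical assay for solubility, at pH 6.8 (a higher number here means a more soluble compound, a lower number a less soluble compound), compound 2 gives 190000 nM and compound 3 gives 200000 nM, two values within the scatter of each other.

Still open, on these data alone, is whether the fluorine atoms or the loss of the ring carries the step in clearance. A plain butyl chain on the same carbonyl carbon would help to separate the two.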